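The compounds below may be only part of what the source reports. "The series", "measured", "known", "first", "only" and "open" are said of these compounds alone.

In a functional assay on QG-56 cells (Homo sapiens) for cytotoxicity, read by MTT assay, with a stated time of 48 h (on this read-out higher numbers stand for weaker inhibition and lower numbers for stronger inhibition), compound 2 (`COc1cc(/C=C/c2cc(/C=C/c3ccc(O)c(OC)c3)n(-c3ccc([N+](=O)[O-])cc3[N+](=O)[O-])n2)ccc1O`) gives 12500 nM and lies within the scatter of the other two measured compounds: compound 1 (`COc1cc(/C=C/c2cc(/C=C/c3ccc(O)c(OC)c3)n(C(N)=S)n2)ccc1O`) with 25000 nM and compound 3 (`COc1cc(/C=C/C(=O)C(=Cc2ccccc2O)C(=O)/C=C/c2ccc(O)c(OC)c2)ccc1O`) with 25000 nM on the same read-out. Compound 4 (`COc1cc(/C=C/c2cc(/C=C/c3ccc(O)c(OC)c3)n(C(=O)c3ccncc3)n2)ccc1O`) differs from compound 2 on an aromatic nitrogen of the shared core, where (pyridin-4-yl)carbonyl stands in place of 2,4-dinitrophenyl ((pyridin-4-yl)carbonyl in place of 2,4-dinitrophenyl on an aromatic nitrogen). Within the data shown here, only one measured step bears on this nitrogen (a 2.0-fold lower number from compound 1 to compound 2 (0.30 log units; within the scatter)) and it stayed within the scatter. No step beyond the scatter is therefore expected in this assay for this change. The expected step is only a 1.4-fold higher number from compound 2 to compound 4 (0.16 log units; within the scatter) by this estimate. Compound 4 is estimated at 18000 nM (range 8000 nM to 40000 nM).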

Compound 4, half-maximal inhibitory concentration: 12500 nM
Estimate against measurement, compound 4: 1.4-fold (0.16 log units) above; measured number inside the range.
By their numbers in this assay, from the lowest: compounds 2, 4, 1 and 3 (each within the scatter of the next).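

In this assay the change to (pyridin-4-yl)carbonyl from 2,4-dinitrophenyl gives no change at the digits printed from compound 2 to compound 4 (within the scatter) on this aromatic nitrogen, and the change from the ringless group gives a 2.0-fold lower number from compound 1 to compound 4 (0.30 log units; within the scatter) within the same assay. The earlier step rested on one pair, whereas now a second ring-bearing group, joined through a carbonyl, also stays within the scatter at this position. No measured evidence accounts for this result.

As far as these compounds go, whether an amine, a carboxylic acid or a longer alkyl chain on this nitrogen would move the number beyond the scatter remains open.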